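The source may report more compounds than this note shows. Statements on the series, on what has been measured and on what is new or still open speak of the compounds shown alone.

Compound 2 `Cc1ccc(C(=O)Nc2nc(Cl)c3cn(CC(C)(C)C)nc3n2)cc1` is the starting point for this step. In an assay on CHO cells for displacement of a labelled ligand from adenosine receptor A1 (Homo sapiens), read by scintillation counting, with a stated time of 3 h (on this read-out higher numbers stand for weaker inhibition and lower numbers for stronger inhibition), compound 2 gives 11100 nM. Among the measured compounds shown here, only one other number is available: compound 3 `CC(C)n1cc2c(Cl)nc(N)nc2n1` gives 9000 nM, and the two values lie within the scatter of each other, so compound 2 stands alongside compound 3 rather than apart from it. Compound 1 `Cc1ccc(C(=O)Nc2nc(Cl)c3cn(C)nc3n2)cc1` is reported only as a limit, > 100000 nM; this is the limit of > 100000 nM in this assay, at which 1 of the 3 values shown sits. For the measured compounds named here, the one measured step, an at least 9.0-fold lower number from compound 1 to compound 2 (0.95 log units; beyond the scatter), concerns the chain on the aromatic nitrogen of the shared core and is the only step beyond the scatter in the set.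

Compound 4 `CC(C)(C)Cn1cc2c(Cl)nc(NC(=O)c3ccc(C(F)(F)F)cc3)nc2n1` differs from compound 2 by trifluoromethyl in place of methyl on an aromatic carbon. Going by the values given here, no measured step touches this aromatic ring; the single step on record concerns the chain carbon and offers no guide for a change on the ring. The expectation is therefore no step beyond the scatter, with a 1.1-fold lower number from compound 2 to compound 4 (0.05 log units; within the scatter) as the estimated change. Compound 4 is expected to give 10000 nM in this assay, with a range from 3000 nM to 35000 nM.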

Compound 4, inhibition constant: > 100000 nM
Compound 4: no number, only a limit; the forecaster's own chance of this, stated with the estimate: 10%; middle value at least 10-fold (1.00 log units) from the limit.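

Among the compounds shown here, the para position on the six-membered aromatic ring of carbon only, para to a large group, now shows a step beyond the scatter, where the only earlier step concerned the chain on the aromatic nitrogen: trifluoromethyl in place of methyl gives an at least 9.0-fold higher number from compound 2 to compound 4 (0.95 log units; beyond the scatter). In this assay compound 4 gives > 100000 nM, which is a limit and not a number. Compound 4 keeps the chain of compound 2, so that chain alone does not keep a compound of this series off the limit: the limit of > 100000 nM in this assay, at which 2 of the 4 values shown sit.

Only methyl and trifluoromethyl are shown at this position, so it stays open how a chlorine atom, a methoxy group or an amine there would read. On these data alone, it also stays open whether the ring position tolerates anything larger than methyl.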